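This account rests on a few compounds, and the source may have more. Where it says the series, first, only, none or still open, it means among the compounds named here.

Compound 1 `CCCNC(=O)c1cc(Oc2ccc(NC(=O)c3nn(-c4ccc(C)cc4)c(=O)cc3C)cc2F)ccn1`, compound 2 `CCNC(=O)c1cc(Oc2ccc(NC(=O)c3nn(-c4ccc(C)cc4)c(=O)cc3C)cc2)ccn1` and compound 3 `CCCNC(=O)c1cc(Oc2ccc(NC(=O)c3nn(-c4cccc(C(F)(F)F)c4)c(=O)cc3C)cc2F)ccn1` were each tested in a functional assay on MCF7 cells (Homo sapiens) for antiproliferative activity, read by MTT assay, with a stated time of 72 h; a lower number here means a stronger inhibitor, a higher number a weaker inhibitor. In this assay compound 1 gives 34600 nM, compound 2 gives 51300 nM and compound 3 gives 30000 nM. One change separates the first and third of these: 3-(trifluoromethyl)phenyl in place of 4-methylphenyl on an aromatic nitrogen. The step it made is a 1.2-fold lower number from compound 1 to compound 3 (0.06 log units; within the scatter). Compound 4 `CCNC(=O)c1cc(Oc2ccc(NC(=O)c3nn(-c4cccc(C(F)(F)F)c4)c(=O)cc3C)cc2)ccn1` carries the same change made on compound 2, namely (3-(trifluoromethyl)phenyl in place of 4-methylphenyl on an aromatic nitrogen); how the core of compound 2 differs from the core of compound 1 is not broken down here. The step from compound 2 to compound 4 in this assay is expected to be small, a 1.2-fold lower number from compound 2 to compound 4 (0.08 log units; within the scatter), because a 1.2-fold lower number from compound 1 to compound 3 (0.06 log units; within the scatter) was small. Compound 4 is therefore estimated at 43000 nM, with a likely range from 20000 nM to 95000 nM.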

Compound 4, half-maximal inhibitory concentration: 40600 nM
Compound 4: the middle estimate sits 1.1-fold (0.02 log units) above what was measured; low and high end bracket the measured number.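

In this assay the swap of 4-methylphenyl for 3-(trifluoromethyl)phenyl brings a 1.3-fold lower number from compound 2 to compound 4 (0.10 log units; within the scatter) on this second core. The swap behaves alike on the two cores, with each step small and the two steps not differing: the same change on two cores in this assay, a 1.2-fold lower number (0.06 log units; within the scatter) from compound 1 to compound 3 and a 1.3-fold lower number (0.10 log units; within the scatter) from compound 2 to compound 4, 1.1-fold (0.04 log units) apart, within the scatter of two such steps

So within this pair of cores, the swap carries over as a change that makes no readable difference to the number. It does not show that the group on the aromatic nitrogen is unimportant, and it does not show that a third core would behave the same way. The compounds shown leave open what a plain phenyl or a pyridine ring would do on that nitrogen. They also leave open whether a longer chain or an amine on the amide, in place of ethyl or propyl, would move the number.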